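The source may report more compounds than this note shows. Statements on the series, on what has been measured and on what is new or still open speak of the compounds shown alone.

Measured so far in an assay for inhibition of inositol hexakisphosphate kinase 2 (Homo sapiens), read by colorimetric assay, coupled enzyme assay and malachite green, with a stated time of 120 min, in the presence of a further agent that is not named here; on this read-out lower numbers stand for stronger inhibition and higher numbers for weaker inhibition:
compound 1 `COC(=O)/C=C/c1ccc2noc(-c3ccccc3)c2c1` gives 1580 nM
compound 2 `CN(C)C(=O)/C=C/c1ccc2noc(-c3ccccc3)c2c1` gives 40300 nM
compound 3 `O=C(O)c1ccc2noc(-c3ccc(-c4cccnc4)cc3)c2c1` gives 54 nM

Compound 3 stands lowest of the three numbers in this assay; compound 1 comes nearest and compound 2 furthest, both beyond the scatter. Compound 4 `CC(C)C(=O)Nc1ccc(-c2onc3ccc(C(=O)O)cc23)cc1` is not yet measured. Its change from compound 3: (isopropylcarbonyl)amino in place of pyridin-3-yl on an aromatic carbon. Among the compounds with values here, the only measured step, a 26-fold higher number from compound 1 to compound 2 (1.41 log units; beyond the scatter), sits on a carbonyl carbon and not on an aromatic carbon, so no measured step bears directly on this change; its size shows only that one exchange of a substituent can move the number far. Compound 3 and compound 4 share the carboxylic acid on the core. Compound 4 is expected at 120 nM, with a range of 30 nM to 500 nM. The expected step is a 2.2-fold higher number from compound 3 to compound 4 (0.35 log units; beyond the scatter), a modest loss not clearly beyond the scatter.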

Compound 4, half-maximal inhibitory concentration: 820 nM
Beside the measured number, compound 4's estimate is 6.8-fold (0.83 log units) below it, outside the stated range (above it).
By their numbers in this assay, from the lowest: compound 3; then compounds 4 and 1 (each within the scatter of the next); then compound 2.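

In this assay, this aromatic carbon, para to a large group, proves sensitive with the carboxylic acid held constant: (isopropylcarbonyl)amino in place of pyridin-3-yl gives a 15-fold higher number from compound 3 to compound 4 (1.18 log units; beyond the scatter). The exchange keeps the heavy-atom count, so that count alone does not fix the number here; a ring gives way to an open group carrying an amide hydrogen. Nothing available accounts for the step.

Still open, on these data alone, is whether the number follows the ring, its nitrogen or the amide hydrogen. A plain phenyl or a methylamino group at this place would help separate these.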